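The source may report more compounds than this note shows. Statements on the series, on what has been measured and on what is new or still open speak of the compounds shown alone.

Measured compounds:
compound 1 `C[Se]c1nc([Se]C)c2cccnc2n1` — "not determined" (no result reported)
compound 2 `[SeH]c1nc([SeH])c2ccccc2n1` — 6010 nM
compound 3 `COc1ccc(CNc2nc(SC)nc3ccccc23)cc1` — > 100000 nM

The set is small. In a functional assay on CCRF-CEM cells (Homo sapiens) for cytotoxicity, read by MTT assay, with a stated time of 72 h (a lower number here means a stronger inhibitor of growth, a higher number a weaker inhibitor of growth), compound 2 gives 6010 nM. For compound 3 the result in this assay is > 100000 nM, which is a limit of the assay rather than a number. For compound 1 there is no result in this assay; its entry reads "not determined" (no result reported). So compound 1 stands nowhere on the numbers shown: the only finished figure is that of compound 2, and the only other entry is the limit of > 100000 nM in this assay, at which 1 of the 3 values shown sits.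

The step to the new compound, compound 4 `C[Se]c1nc(N)c2cccnc2n1`, replaces one of the two methylselanyl groups of compound 1 with an amino group. In detail, (one nitrogen atom in place of a group of 2 heavy atoms (1 carbon, 1 selenium; no ring), on an aromatic carbon). Among the compounds with values here, no measured pair shares this change, and compound 1 itself is unmeasured, so no direction can be read from the data. With no comparison available, the expectation for compound 4 in this assay can only be placed by the two finished entries, which span from the number of compound 2 up to the limit of compound 3, and the estimate is wide. Compound 4 is expected to give about 20000 nM, within a range from 3000 nM to 100000 nM.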

Compound 4, concentration for total growth inhibition: > 100000 nM
Compound 4: a limit, no number; the forecaster's own chance of this, stated with the estimate: 35%; middle value at least 5.0-fold (0.69 log units) from the limit.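

In this assay compound 4 gives > 100000 nM, which is a limit and not a number. Compound 1 has no number either, so no step can be read between compound 1 and compound 4. The compounds shown leave open how the amino group of compound 4 compares with the group it replaces in compound 1.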